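The compounds below may be only part of what the source reports. "The series", "measured", "known", "first", "only" and "open" are said of these compounds alone.

Compound 1 `CC(C)(C)c1ccc(OCCCCN2CCN(c3ncccn3)CC2)cc1` gives 11.3 nM in a functional assay on L5178Y cells (Mus musculus) for antiproliferative activity, read by MTT assay; on this read-out higher numbers stand for weaker inhibition and lower numbers for stronger inhibition. Compound 2 `CC(=O)c1ccc(OCCCCN2CCN(c3ncccn3)CC2)cc1` gives 31.6 nM. Compound 3 `CC(=O)c1ccc(OCCCN2CCN(c3ccncc3)CC2)cc1` gives 42.3 nM.

Among these three, compound 1 stands lowest: the step of a 2.8-fold higher number from compound 1 to compound 2 (0.45 log units; beyond the scatter) moves away from it, and compound 3 sits further from it still. Compound 4 `CC(C)(C)c1ccc(OCCCCN2CCN(c3cnccn3)CC2)cc1` differs from compound 1 by pyrazin-2-yl in place of pyrimidin-2-yl on an amine nitrogen in a ring. Among the measured compounds shown here, none of the measured steps touches this ring; the only single-point step, a 2.8-fold higher number from compound 1 to compound 2 (0.45 log units; beyond the scatter), changes a group on an aromatic carbon, and compound 3 differs from the others in more than one place. The change is therefore expected to stay within the usual scatter, an expected step of a 1.3-fold higher number from compound 1 to compound 4 (0.12 log units; within the scatter). Compound 4 is estimated at 15 nM, between 6 nM and 40 nM.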

Compound 4, half-maximal inhibitory concentration: 9.86 nM
For compound 4 the middle estimate is 1.5-fold (0.18 log units) above the measured one; the range from low to high includes it.
By their numbers in this assay, from the lowest: compounds 4 and 1 (each within the scatter of the next); then compounds 2 and 3 (each within the scatter of the next).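

Among the compounds shown here, this is the first single change at the amine nitrogen in a ring: pyrazin-2-yl in place of pyrimidin-2-yl gives a 1.1-fold lower number from compound 1 to compound 4 (0.06 log units; within the scatter) in this assay. Both groups are six-membered aromatic rings with the same atoms, joined differently, and on this read-out the two cannot be told apart. No measurement at hand bears on why this is so.

On these data alone, what remains open is whether phenyl, a ring with no nitrogen, or a simple methyl on the same nitrogen would also stay within the scatter of compound 1.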